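Shifting a Trifluoromethyl Group Across Two Related Cores

This account rests on a few compounds, and the source may have more. Where it says the series, first, only, none or still open, it means among the compounds named here.

Three compounds that share a central six-membered aromatic ring with one nitrogen have been tested in a functional assay on HeLa cells (Homo sapiens) for inhibition; a lower number here means a stronger inhibitor, a higher number a weaker inhibitor. Compound 1 `Oc1ccccc1-c1cc(-c2cccc(C(F)(F)F)c2)cc(-c2ccccc2O)n1` carries a 3-(trifluoromethyl)phenyl group and two 2-hydroxyphenyl groups. In this assay compound 1 gives only a limit, > 50000 nM. Compound 2 `Oc1ccccc1-c1cc(-c2ccc(C(F)(F)F)cc2)cc(-c2ccccc2O)n1` is its counterpart with 4-(trifluoromethyl)phenyl in place of 3-(trifluoromethyl)phenyl on an aromatic carbon. In this assay compound 2 also returns a limit, > 50000 nM. The step that the two limits leave unreadable from compound 1 to compound 2 therefore cannot be sized, since it runs between two readings at the limit of > 50000 nM in this assay, at which 2 of the 3 values shown sit. Compound 3 `Oc1cccc(-c2cc(-c3cccc(C(F)(F)F)c3)cc(-c3cccc(O)c3)n2)c1` bears 3-hydroxyphenyl groups; how its core differs from that of compound 1 is not broken down here. In this assay, among the measured compounds shown here, compound 3 gives 12700 nM, the only number among the three. Compound 4 `Oc1cccc(-c2cc(-c3ccc(C(F)(F)F)cc3)cc(-c3cccc(O)c3)n2)c1`, not yet measured, applies the same kind of change to the core of compound 3 (4-(trifluoromethyl)phenyl in place of 3-(trifluoromethyl)phenyl on an aromatic carbon); around the place, the ring now carries two 3-hydroxyphenyl groups rather than two 2-hydroxyphenyl groups. Because a step that the two limits leave unreadable from compound 1 to compound 2 is unreadable, no measured size of this change is available to lean on. For compound 4 the expected step is a 1.6-fold higher number from compound 3 to compound 4 (0.20 log units; within the scatter), a cautious guess that the shift changes little. Compound 4 is estimated at 20000 nM, within 6000 nM to 50000 nM.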

Compound 4, half-maximal inhibitory concentration: > 50000 nM
Compound 4: a limit, no number; the forecaster's own chance of this, stated with the estimate: 35%; middle value at least 2.5-fold (0.39 log units) away from the limit.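

In this assay, swapping 3-(trifluoromethyl)phenyl for 4-(trifluoromethyl)phenyl on the core bearing two 3-hydroxyphenyl groups gives an at least 3.9-fold higher number from compound 3 to compound 4 (0.59 log units; beyond the scatter), so on this core the change weakens inhibition. Going by these compounds, the true size of this step remains unknown, and only its minimum can be stated, because compound 4 gives a limit rather than a number: the limit of > 50000 nM in this assay, at which 3 of the 4 values shown sit. The same change on the core of compound 1 cannot be read, since both of its ends are limits, so the data do not show whether the change has the same effect on both cores or carries from one to the other.

On these data alone, it remains open whether a nitrile or an amine in place of the trifluoromethyl group would give a lower number than compound 3. Also open, as far as these compounds go, is how a methoxy group in place of each hydroxyl would read on this core, with either 3-(trifluoromethyl)phenyl or 4-(trifluoromethyl)phenyl attached.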